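This account rests on a few compounds, and the source may have more. Where it says the series, first, only, none or still open, it means among the compounds named here.

Compound 1 `Cc1ccc(S(=O)(=O)N(Cc2nnc(Cc3ccccc3F)o2)c2cccc(Cl)c2C)cc1` gives 501 nM in an assay on CHO cells for displacement of a labelled ligand from prostaglandin E2 receptor EP1 subtype (Homo sapiens); on this read-out higher numbers stand for weaker inhibition and lower numbers for stronger inhibition; compound 2 `Cc1ccc(S(=O)(=O)N(Cc2nnc(Cc3cccc(Cl)c3)o2)c2cccc(Cl)c2C)cc1` gives 158 nM in the same assay.

Compound 2 has the lowest number of the two shown; its nearest neighbour is compound 1, and the step of a 3.2-fold lower number from compound 1 to compound 2 (0.50 log units; beyond the scatter) lies beyond the scatter. Compound 3 `Cc1ccc(S(=O)(=O)N(Cc2nnc(Cc3ccc(Cl)cc3Cl)o2)c2cccc(Cl)c2C)cc1` is not yet measured. It differs from compound 2 by 2,4-dichlorophenyl in place of 3-chlorophenyl on a saturated chain carbon bound to an aromatic carbon. Among the measured compounds shown here, the only measured step that bears on this part of the molecule is the one from compound 1 to compound 2, which changed the halogen pattern on the same phenyl and was modest in size. For the measured compounds named here, no measured pair tells how a second chlorine on that ring behaves, so the direction is uncertain, and compound 3 is expected to move by a 1.3-fold higher number from compound 2 to compound 3 (0.10 log units; within the scatter), likely within the scatter. The estimate for compound 3 is 200 nM, with a range from 60 nM to 630 nM.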

Compound 3, half-maximal inhibitory concentration: 63.1 nM
Compound 3: middle estimate off by 3.2-fold (0.50 log units), on the high side, within the range that was stated.
By their numbers in this assay, from the lowest: compound 3; then compound 2; then compound 1.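

In this assay, 2,4-dichlorophenyl, with one chlorine more than 3-chlorophenyl, gives a 2.5-fold lower number from compound 2 to compound 3 (0.40 log units; beyond the scatter), so a second chlorine on this ring is compatible with stronger inhibition at this position. Across the series, the change from 2-fluorophenyl to 2,4-dichlorophenyl gives a 7.9-fold lower number from compound 1 to compound 3 (0.90 log units; beyond the scatter), the largest step seen here, and the three compounds order as 2-fluorophenyl, 3-chlorophenyl and then 2,4-dichlorophenyl, from weakest to strongest inhibition. Nothing available accounts for this order.

As far as these compounds go, whether the lower number follows the count of chlorines or their arrangement stays open, as this step alters both at once. From the compounds shown here alone, how a methoxy or trifluoromethyl group on this ring, or a pyridine ring in place of the phenyl, would behave also remains unknown.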